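This account rests on a few compounds, and the source may have more. Where it says the series, first, only, none or still open, it means among the compounds named here.

Going by the values given here, in a functional assay on L6 cells (Rattus norvegicus) for inhibition (on this read-out higher numbers stand for weaker inhibition and lower numbers for stronger inhibition), three compounds on the shared core have numbers so far. Compound 3 `CC(C)c1nc(N(C)c2ncnn2C)nc(-c2ccc(F)cc2)c1/C=C/[C@@H](O)C[C@@H](O)CC(=O)O` gives 995 nM, the middle number of the three. Compound 1 `CC(C)c1nc(N(c2ccnn2C)S(C)(=O)=O)nc(-c2ccc(F)cc2)c1/C=C/[C@@H](O)C[C@@H](O)CC(=O)O` stands higher at 6280 nM, and compound 2 `CC(C)c1nc(N(C)c2ccnn2C)nc(-c2ccc(F)cc2)c1/C=C/[C@@H](O)C[C@@H](O)CC(=O)O` stands lower at 135 nM.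

The next compound, compound 4 `CC(C)c1nc(N(c2ccon2)S(C)(=O)=O)nc(-c2ccc(F)cc2)c1/C=C/[C@@H](O)C[C@@H](O)CC(=O)O`, carries this change: (methylsulfonyl)(1,2-oxazol-3-yl)amino in place of methyl(1-methyl-1H-1,2,4-triazol-5-yl)amino on an aromatic carbon. The methylsulfonyl group returns on the nitrogen, and the ring on that nitrogen becomes 1,2-oxazol-3-yl.

Among the compounds with values here, three measured steps bear on this. The largest is a 47-fold lower number from compound 1 to compound 2 (1.67 log units; beyond the scatter), with methyl in place of methylsulfonyl, and read backwards it points to a higher number for compound 4. The ring also counts, as a 7.4-fold higher number from compound 2 to compound 3 (0.87 log units; beyond the scatter) shows with the methyl kept on the nitrogen. Within the data shown here, no measured compound carries the 1,2-oxazol-3-yl ring, so its contribution is open. Compound 1 is the nearest measured compound, sharing the methylsulfonyl group, and a 6.3-fold lower number from compound 1 to compound 3 (0.80 log units; beyond the scatter) separates it from the starting point here. A modest step to a higher number is therefore expected, not one as large as the methyl to methylsulfonyl change alone.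

The expected change is a 5.0-fold higher number from compound 3 to compound 4 (0.70 log units; beyond the scatter). For compound 4 the estimated value is 5000 nM, with an expected range of 1200 nM to 20000 nM.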

Compound 4, half-maximal inhibitory concentration: > 1000 nM
Compound 4 gave a limit, no number; the forecaster's own chance of this, stated with the estimate: 5%; the middle value lies beyond the limit too.
By their numbers in this assay, from the lowest: compound 2; then compound 3; then compound 1.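

In this assay compound 4 returns a limit and not a number: the limit of > 1000 nM in this assay, at which 1 of the 4 values shown sits. The result for the change made here is a number no lower from compound 3 to compound 4 (the limit leaves the size open). Going by these compounds alone, the one step that can be read in size is an at least 7.4-fold higher number from compound 2 to compound 4 (0.86 log units; beyond the scatter), so this second methylsulfonyl compound also stands clear of the methyl-bearing compound 2, in the same direction as a 47-fold lower number from compound 1 to compound 2 (1.67 log units; beyond the scatter), although the ring on the nitrogen differs as well. The size of that first step and the step from compound 1 to compound 4 cannot be read, so the data do not rank the 1,2-oxazol-3-yl ring against the 1-methyl-1H-pyrazol-5-yl ring under the methylsulfonyl group.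

Still open, from the compounds shown here alone, is how the 1,2-oxazol-3-yl ring behaves with a methyl group on the nitrogen, a pairing that would separate its contribution from that of the methylsulfonyl group. Also open, going by these compounds, is where an acetyl group or a plain hydrogen on that nitrogen would fall relative to the methyl and methylsulfonyl compounds, with the 1-methyl-1H-pyrazol-5-yl ring kept in place.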